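The source may report more compounds than this note shows. Statements on the series, on what has been measured and on what is new or still open speak of the compounds shown alone.

Of the compounds shown here, three have so far been tested in a functional assay on MCF7 cells (Homo sapiens) for cytotoxicity, read by MTT assay, with a stated time of 72 h; on this read-out higher numbers stand for lower toxicity in this test and lower numbers for higher toxicity in this test. Compound 1 `CCCCC[Se]c1nc(NCc2ccccc2)c2ccccc2n1` gives 99400 nM in this assay. Compound 2 `[SeH]c1nc(NCc2ccccc2)c2ccccc2n1` carries a hydrogen on the selenium where compound 1 has a pentyl chain; in this assay compound 2 reaches only the limit of the test, > 100000 nM. The change between them is pentyl in place of hydrogen on a selenium, and the step it made was a number no higher from compound 2 to compound 1 (the limit leaves the size open). Compound 3 `Nc1nc([SeH])nc2ncccc12` has a different core; how its core differs from that of compound 2 is not broken down here. In this assay compound 3 also stops at the limit, > 100000 nM. Compound 4 `CCCCC[Se]c1nc(N)c2cccnc2n1` has not yet been measured; it arises from compound 3 by pentyl in place of hydrogen on a selenium, the same change as from compound 2 to compound 1, at the same place. Among the compounds with values here, since two of the three values so far sit at the limit of > 100000 nM in this assay, at which 2 of the 3 values shown sit, the earlier step gives little to go on. For compound 4 the step is expected to be about a number no higher from compound 3 to compound 4 (the limit leaves the size open). That expectation rests on compound 1 having given 99400 nM. Compound 4 is therefore estimated at 100000 nM, somewhere between 40000 nM and 250000 nM.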

Compound 4, concentration lethal to 50% of the cells: 85000 nM
Estimate against measurement, compound 4: 1.2-fold (0.07 log units) above, and the stated range covers the measured number.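

Putting pentyl in place of hydrogen on a selenium gave, in this assay, an at least 1.1-fold lower number from compound 3 to compound 4 (0.07 log units; that floor lies within the scatter). Set side by side, the two cases read as follows: the same change on two cores in this assay, a number no higher (the limit leaves the size open) from compound 2 to compound 1 and an at least 1.1-fold lower number (0.07 log units; that floor lies within the scatter) from compound 3 to compound 4; the limit leaves it open whether they differ The result therefore shows nothing that conflicts with carrying this change from one core to the other, but it does not show that the step has the same size on both cores, since neither step has a readable size when its starting compound gives no number, only a limit: the limit of > 100000 nM in this assay, at which 2 of the 4 values shown sit.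

The compounds shown leave open what a shorter chain such as methyl or a longer chain such as octyl on the selenium would do on either core. They also leave open whether a pentyl chain carrying an amine or a carboxylic acid would give a number clearly different from those of the pentyl compounds.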